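The compounds below may be only part of what the source reports. "The series", "measured", "known", "first", "only" and "open" are said of these compounds alone.

Measured compounds:
Compound 1 `CCOC(=O)c1sc2ccc(NCc3c[nH]cn3)cc2c1NC(=O)c1ccc(F)c(Cl)c1`: 10700 nM
Compound 2 `CCOC(=O)c1sc2ccc(NCc3nc[nH]c3C)cc2c1NC(=O)c1ccc(C)cc1`: 11400 nM

Of the compounds shown here, two share one core and have been tested in a functional assay on HeLa cells (Homo sapiens) for antiproliferative activity, read by MTT assay, with a stated time of 48 h; a lower number here means a stronger inhibitor of growth, a higher number a weaker inhibitor of growth. Compound 1 gives 10700 nM in this assay. Compound 2 gives 11400 nM in this assay, the higher of the two numbers, though its gap to compound 1 lies within the usual scatter, so the two cannot be ranked against each other.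

Compound 3 `CCOC(=O)c1sc2ccc(NCc3nc[nH]c3C)cc2c1NC(=O)c1ccc(F)c(Cl)c1` has not yet been measured. It is reached from compound 2 by one change: 3-chloro-4-fluorophenyl in place of 4-methylphenyl on a carbonyl carbon. The amide side of the molecule therefore carries the same ring as compound 1 does, while the rest of compound 3 stays as in compound 2. Going by the values given here, since no single-point step between the measured compounds is available, the only guide is that both measured numbers sit close together in this assay. The change from compound 2 to compound 3 is therefore expected to bring no shift beyond the scatter, an expected step of a 1.1-fold lower number from compound 2 to compound 3 (0.04 log units; within the scatter). Compound 3 is estimated at 10500 nM in this assay, with a range from 5000 nM to 22000 nM.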

Compound 3, concentration for 50% growth inhibition: 2910 nM
Compound 3: middle estimate off by 3.6-fold (0.56 log units), on the high side; the measured number lies below the stated range.
By their numbers in this assay, from the lowest: compound 3; then compounds 1 and 2 (each within the scatter of the next).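

In this assay, putting 3-chloro-4-fluorophenyl in place of 4-methylphenyl on a carbonyl carbon, with the rest of the molecule unchanged, gives a 3.9-fold lower number from compound 2 to compound 3 (0.59 log units; beyond the scatter), so the group at this position does affect growth inhibition. With 3-chloro-4-fluorophenyl held constant, methyl in place of hydrogen on an aromatic carbon gives a 3.7-fold lower number from compound 1 to compound 3 (0.57 log units; beyond the scatter), showing that this second, much smaller change also counts; compound 1 and compound 2 differ in both places, so their close numbers could not reveal either step alone. No measurement shown here gives a reason for either step.

Going by these compounds alone, it remains open whether the methyl brings a similar step when 4-methylphenyl sits on the carbonyl, since only one single-place comparison of that methyl is available. It is also unclear whether a phenyl carrying chlorine alone or fluorine alone would match 3-chloro-4-fluorophenyl, or how an ethyl in place of the methyl would behave.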